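Microsomal stability across a pyrrolopyridine-linked pyridone series

The compounds below may be only part of what the source reports. "The series", "measured", "known", "first", "only" and "open" are said of these compounds alone.

Measured so far:
- compound 1 `CC(C)n1cc(-c2ccnc3[nH]c(C4CCNCC4)cc23)ccc1=O`: < 3 uL/min
- compound 2 `COc1cc(C(=O)N2CCCC2)ccc1-c1ccnc2[nH]c(C3CCOCC3)cc12`: 74 uL/min
- compound 3 `CC(C)Cn1cc(-c2ccnc3[nH]c(C4CCN(CC(=O)N(C)C)CC4)cc23)ccc1=O`: 21 uL/min

Three compounds have been run in an ADME assay on microsomes from liver (Homo sapiens) for metabolic stability; on this read-out higher numbers stand for fast clearance and lower numbers for slow clearance. Compound 1 `CC(C)n1cc(-c2ccnc3[nH]c(C4CCNCC4)cc23)ccc1=O` returns only a limit of the assay, < 3 uL/min, rather than a number (the limit of < 3 uL/min in this assay, at which 1 of the 3 values shown sits). Of the two numbers, compound 3 `CC(C)Cn1cc(-c2ccnc3[nH]c(C4CCN(CC(=O)N(C)C)CC4)cc23)ccc1=O` gives the lower one, 21 uL/min, while compound 2 `COc1cc(C(=O)N2CCCC2)ccc1-c1ccnc2[nH]c(C3CCOCC3)cc12` gives 74 uL/min, a gap that lies beyond the usual scatter. No two of these compounds differ in a single place, so no measured step can be read from them.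

Compound 4 `CN(C)C(=O)CN1CCC(c2cc3c(-c4ccc(=O)n(C5CCOCC5)c4)ccnc3[nH]2)CC1` is the next analogue and is not yet measured. Relative to compound 3 it differs in one place: oxan-4-yl in place of isobutyl on an aromatic nitrogen. Within the data shown here, with no measured step to lean on, the change is expected to move this assay only modestly, if at all, toward slower clearance, and the step from compound 3 to compound 4 is estimated at a 1.5-fold lower number from compound 3 to compound 4 (0.18 log units; within the scatter). Compound 4 is accordingly expected to give 14 uL/min in this assay, within a range of 5 uL/min to 35 uL/min.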

Compound 4, intrinsic clearance in a liver preparation (reported as CLH), per the amount of preparation that the assay uses: 8.2 uL/min
The estimate for compound 4 lay 1.7-fold (0.23 log units) above the measured number, within the range that was stated.
By their numbers in this assay, from the lowest: compound 4; then compound 3; then compound 2. At a limit, below all of these: compound 1.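

Working notes on the aromatic nitrogen: in this assay, oxan-4-yl in place of isobutyl gives a 2.6-fold lower number from compound 3 to compound 4 (0.41 log units; beyond the scatter), the only single-place step shown for the series. The read-out therefore responds to the group at this position, and on this one pair the larger group, with its ring and hydrogen-bond acceptor, goes with the lower number rather than a higher one. Nothing at hand accounts for the size or direction of this step.

One pair cannot separate the contribution of the ring from that of its oxygen, and a comparison with cyclohexyl, the all-carbon ring, would bear on that question. On these data alone, it also remains open whether the step carries over when the dimethylamide side chain on the piperidine nitrogen is replaced by another group, such as a carboxylic acid.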